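Heptyloxy to fluoro: from compound 3 to compound 4

A few compounds are considered here, and "the series" means these few. Any claim that something is new, unique, unknown or untested is made for them only; others in the source may bear on it.

In a functional assay on HL-60 cells (Homo sapiens) for cytotoxicity, read by WST assay, with a stated time of 48 h (a higher number here means that more compound is needed for the effect, a lower number that less compound is needed), compound 1 `O=C1OC[C@H](Cc2ccccc2)[C@H]1Cc1ccccc1Cl` gives 37000 nM and compound 2 `COCOc1ccc(C[C@H]2C(=O)OC[C@@H]2Cc2ccccc2)cc1` gives 71000 nM as measured values, and these two lie within the usual scatter of each other. Compound 3 `CCCCCCCOc1ccc(C[C@H]2C(=O)OC[C@@H]2Cc2ccccc2)cc1` gives > 100000 nM as its reading, which is a limit of the assay and not a number. Compound 3 is known only through the limit of > 100000 nM in this assay, at which 1 of the 3 values shown sits, and has no number to rank against the others.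

Compound 4 `O=C1OC[C@H](Cc2ccccc2)[C@H]1Cc1ccc(F)cc1` follows from compound 3 by the change fluoro in place of heptyloxy on an aromatic carbon at a site para to a large group. For the measured compounds named here, the one measured step within that substituent is an at least 1.4-fold higher number from compound 2 to compound 3 (0.14 log units; that floor lies within the scatter) and its floor lies within the scatter, so it fixes no size for the change here. The nearest guide is compound 1 at 37000 nM as the measured compound that also carries a halogen on an aromatic ring. A reading in this assay that returns to the measured range is therefore expected. The expected step is an at least 2.2-fold lower number from compound 3 to compound 4 (0.34 log units; beyond the scatter) toward a lower number, and its size remains an estimate. For compound 4 the estimated value is 45000 nM with an expected range from 18000 nM to 100000 nM in this assay.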

Compound 4, half-maximal effective concentration: 57000 nM
The estimate for compound 4 lay 1.3-fold (0.10 log units) below the measured number; the range from low to high includes it.
By their numbers in this assay, from the lowest: compounds 1, 4 and 2 (each within the scatter of the next). At a limit, above all of these: compound 3.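

In this assay, fluoro on an aromatic carbon, para to a large group, returns this position to a measured number where heptyloxy gave only a limit, but the step is an at least 1.7-fold lower number from compound 3 to compound 4 (0.24 log units; that floor lies within the scatter), which fixes no size for the change. Fluoro and methoxymethoxy at this position are not separated by a 1.2-fold lower number from compound 2 to compound 4 (0.10 log units; within the scatter), so the series so far shows no difference between a single halogen and this short oxygen-bearing substituent. The swap of 2-chlorophenyl for 4-fluorophenyl, at a 1.5-fold higher number from compound 1 to compound 4 (0.19 log units; within the scatter), likewise sets no order between these two halogen-bearing rings, and all three measured compounds remain within the scatter of the next in line.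

How far heptyloxy really lies from the others stays open, since compound 3 is still a limit of the assay and not a number: the limit of > 100000 nM in this assay, at which 1 of the 4 values shown sits.

Also open, from the compounds shown here alone, is whether an amine or a carboxylic acid at this aromatic carbon, or an alkoxy chain of a length between methoxymethoxy and heptyloxy, would give a step beyond the scatter in this assay.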